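Ketone chain variation in a positive allosteric modulator series

The source may hold more compounds than are shown below. What is called first, only, known or untested is meant among the compounds shown, and "the series" means these compounds.

Measured so far:
compound 1, `CCC(=O)c1ccc(OCCCCOc2cc(C(=O)O)ccc2OC)c(C)c1O`: 6360 nM
compound 2, `Cc1c(OCCCCOc2ccc(C(=O)O)cc2Cl)ccc(C(=O)CC(C)C)c1O`: 1140 nM

Compound 1 stands at the highest number of the two, and compound 2 sits at a lower number than compound 1 by a margin beyond the scatter. Within the data shown here, in an assay on HEK293 cells for positive allosteric modulation of metabotropic glutamate receptor 3 (Rattus norvegicus), read by thallium flux, with a stated time of 2.5 min (on this read-out lower numbers stand for an effect already at smaller amounts and higher numbers for an effect only at larger amounts of compound), compound 1 gives 6360 nM and compound 2 gives 1140 nM; compound 2 differs from compound 1 in more than one place, so no single step between them is defined.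

Compound 3, `COc1ccc(C(=O)O)cc1OCCCCOc1ccc(C(=O)CC(C)C)c(O)c1C`, is not yet measured. It differs from compound 1 in one place: isopropyl in place of methyl on a saturated chain carbon bound to a carbonyl carbon. The same ketone chain is present in compound 2, which is the only hint available, and compound 2 also carries a different substituent on the acid-bearing ring, so the hint is indirect. The step from compound 1 to compound 3 is expected to be a move towards a lower number, of a size beyond the scatter, a 3.3-fold lower number from compound 1 to compound 3 (0.52 log units; beyond the scatter). Compound 3 is accordingly estimated at 1900 nM, with a range from 700 nM to 5000 nM.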

Compound 3, half-maximal effective concentration: 737 nM
Beside the measured number, compound 3's estimate is 2.6-fold (0.41 log units) above it; measured number inside the range.
By their numbers in this assay, from the lowest: compounds 3 and 2 (each within the scatter of the next); then compound 1.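

In this assay, isopropyl in place of methyl on a saturated chain carbon bound to a carbonyl carbon gives an 8.6-fold lower number from compound 1 to compound 3 (0.94 log units; beyond the scatter), with the rest of the structure unchanged. Among these compounds, this is the first reading of the ketone chain as a single change, which compound 1 and compound 2 could not give because they differ in more than one place; it shows that the number at this position responds to the end of the chain alone. Nothing at hand accounts for the size of this step.

Open, from the compounds shown here alone, is whether the added carbons or the branching carry the step, which an unbranched longer chain or a cyclopropyl group at the same place would separate. Also open, going by these compounds, is whether the same change gives a step of similar size with the chlorine-bearing acid ring of compound 2.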